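The source may hold more compounds than are shown below. What is called first, only, known or untested is meant among the compounds shown, and "the series" means these compounds.

Measured in a functional assay on DU-145 cells (Homo sapiens) for inhibition, read by trypan blue exclusion, with a stated time of 72 h; a lower number here means a stronger inhibitor, a higher number a weaker inhibitor:
- compound 1 `Cn1c(=O)c(S(=O)(=O)Cc2ccc(F)cc2F)cc2cnc(Nc3ccc4[nH]ccc4c3)nc21`: 1000 nM
- compound 2 `Cn1c(=O)c(S(=O)(=O)c2ccccc2)cc2cnc(Nc3ccc4ncccc4c3)nc21`: 50000 nM
- compound 3 `Cn1c(=O)c(S(=O)(=O)c2ccc(F)cc2F)cc2cnc(Nc3ccc4sccc4c3)nc21`: 500 nM

Compound 1 stands within the scatter of compound 3, so these two cannot be ordered on the present numbers. Compound 2 has a much higher number than compound 1, and that gap lies beyond the scatter.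

The next step leads to compound 4 `Cn1c(=O)c(S(=O)(=O)c2ccc(Cl)cc2)cc2cnc(Nc3ccc4[nH]ccc4c3)nc21`, which keeps the rest of compound 1 and changes one group, with 4-chlorophenyl in place of 2,4-difluorobenzyl on a sulfonyl sulfur.

Going by the values given here, no measured pair differs in one place only, so the effect of this swap has not been observed directly. Compound 3 gives 500 nM and compound 2 gives 50000 nM, and both also have a ring directly on the sulfonyl sulfur. These two differ elsewhere too, so their wide gap cannot be assigned to any one group, and it calls for a broad range.

In this assay, no step beyond the scatter is expected, in either direction. The estimated step is a 1.3-fold lower number from compound 1 to compound 4 (0.10 log units; within the scatter). For compound 4 the expected value is 800 nM, with an estimated range of 150 nM to 5000 nM.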

Compound 4, half-maximal inhibitory concentration: 250 nM
Compound 4: middle estimate off by 3.2-fold (0.51 log units), on the high side; the measured number falls inside the stated range.
By their numbers in this assay, from the lowest: compounds 4, 3 and 1 (each within the scatter of the next, the first and the last beyond it); then compound 2.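

In this assay, 4-chlorophenyl in place of 2,4-difluorobenzyl on a sulfonyl sulfur gives a 4.0-fold lower number from compound 1 to compound 4 (0.60 log units; beyond the scatter). Going by these compounds alone, this is the first change that can be read in one place, and it shows a modest shift from the group on this sulfur alone, with the rest of compound 1 held fixed. Several things change at once, however: the entering group has 7 heavy atoms against 9, carries chlorine instead of fluorine, and has its ring directly on the sulfur, and no measurement at hand bears on the cause of the step.

Still open, on these data alone, is whether the ring placement on the sulfur or the halogen pattern decides the number, a question that 4-chlorobenzyl or 2,4-difluorophenyl on the core of compound 1 would separate. Also open, as far as these compounds go, is how the position answers to groups of another kind, such as an amine, a carboxylic acid on the ring, or a longer chain such as phenethyl on the sulfonyl sulfur.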